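Piperidine in place of the anilino group on the core

The source may report more compounds than this note shows. Statements on the series, on what has been measured and on what is new or still open speak of the compounds shown alone.

Compound 1 `CC(C(=O)NCc1ccc(C(F)(F)F)nc1Nc1ccc(F)cc1)c1ccc(NS(C)(=O)=O)c(F)c1` holds the higher of the two numbers measured in a functional assay on CHO-K1 cells for antagonist activity at transient receptor potential cation channel subfamily V member 1 (Homo sapiens), read by FLIPR (a lower number here means a stronger inhibitor, a higher number a weaker inhibitor), giving 39.2 nM. Among the compounds with values here, compound 2 `CC(C(=O)NCc1ccc(C(F)(F)F)nc1N1CCCCC1C)c1ccc(NS(C)(=O)=O)c(F)c1` gives 2.9 nM in this assay, and the single measured step, a 14-fold lower number from compound 1 to compound 2 (1.13 log units; beyond the scatter), bears directly on the change at hand. Compound 3 `CC(C(=O)NCc1ccc(C(F)(F)F)nc1N1CCC(C(F)(F)F)CC1)c1ccc(NS(C)(=O)=O)c(F)c1` differs from compound 1 as 4-(trifluoromethyl)piperidin-1-yl in place of (4-fluorophenyl)amino on an aromatic carbon. Again a six-membered non-aromatic ring with 1 hetero atom replaces the (4-fluorophenyl)amino group, so a large drop is expected for compound 3, a 6.5-fold lower number from compound 1 to compound 3 (0.82 log units; beyond the scatter). Within the data shown here, the only known step carries a different ring substituent, so the expected step is set a little smaller. Compound 3 is estimated at 6 nM, within 2 nM to 20 nM.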

Compound 3, inhibition constant: 0.6 nM
The estimate for compound 3 lay 10-fold (1.00 log units) above the measured number; measured number below the stated range.
By their numbers in this assay, from the lowest: compound 3; then compound 2; then compound 1.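

In this assay the gain at this position is not confined to the 2-methylpiperidin-1-yl group: 4-(trifluoromethyl)piperidin-1-yl in place of (4-fluorophenyl)amino also lowers the number (a 65-fold lower number from compound 1 to compound 3 (1.82 log units; beyond the scatter)). The choice of piperidine also matters, since the two rings are separated by a modest step beyond the scatter (a 4.8-fold lower number from compound 2 to compound 3 (0.68 log units; beyond the scatter)). No available data account for either step.

Compounds 2 and 3 differ in both the substituent and its place on the piperidine, so those two effects remain unseparated. A 4-methylpiperidin-1-yl or unsubstituted piperidin-1-yl group would help to separate them.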